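The source may report more compounds than this note shows. Statements on the series, on what has been measured and on what is new or still open speak of the compounds shown alone.

Measured so far in a physicochemical assay for solubility, using the shake flask method, with a stated time of 12 h; a higher number here means a more soluble compound, a lower number a less soluble compound:
- compound 1 `O=C(/C=C/c1ccccc1O)/C=C/c1cccc(O)c1O`: 151000 nM
- compound 2 `O=C(/C=C/c1cccc(O)c1)/C=C/c1cccc(O)c1O`: 184000 nM

Not yet measured: compound 3 `O=C(/C=C/c1ccc(O)cc1)/C=C/c1cccc(O)c1O`.

On the two numbers available, compound 2 gives 184000 nM in this assay, and this lies within the scatter of the number for compound 1. Neither compound can be placed ahead of the other.

The next step puts 4-hydroxyphenyl in place of 3-hydroxyphenyl on a double-bonded chain carbon bound to a double-bonded chain carbon. The rest of the structure stays the same.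

Among the compounds with values here, only one measured step bears on this change. It is a 1.2-fold higher number from compound 1 to compound 2 (0.09 log units; within the scatter), with 3-hydroxyphenyl in place of 2-hydroxyphenyl at the same place. That single step is a thin basis and says nothing directly about 4-hydroxyphenyl, so the range is kept wide. Within the data shown here, with compound 2 as the starting point and the one related step inside the scatter, no step beyond the scatter is expected in this assay, and no direction is favoured. The estimated step is a 1.2-fold lower number from compound 2 to compound 3 (0.06 log units; within the scatter).

For compound 3 the expected value is 160000 nM, with an estimated range of 75000 nM to 330000 nM.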

Compound 3, solubility: 120000 nM
Beside the measured number, compound 3's estimate is 1.3-fold (0.12 log units) above it; the range from low to high includes it.
By their numbers in this assay, from the lowest: compounds 3, 1 and 2 (each within the scatter of the next).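

Swapping the hydroxyphenyl groups at this place on a double-bonded chain carbon bound to a double-bonded chain carbon now covers 2-hydroxyphenyl, 3-hydroxyphenyl and 4-hydroxyphenyl, and in this assay the new readings are a 1.5-fold lower number from compound 2 to compound 3 (0.19 log units; within the scatter) and a 1.3-fold lower number from compound 1 to compound 3 (0.10 log units; within the scatter) for the two comparisons with 4-hydroxyphenyl. With these two steps added to the earlier one, every pair among the three compounds lies within the scatter, so the three groups cannot be told apart by this read-out and none can be preferred on solubility. No supporting measurement is available to account for these numbers.

The compounds shown all carry a hydroxyphenyl group at this place, so it remains open whether a different group there, such as an amine, a carboxylic acid or a methoxyphenyl, would give a step beyond the scatter. Changes elsewhere on the shared core also remain open, as does whether the similarity among these three compounds would persist with a different group at those other places.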